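The source may hold more compounds than are shown below. What is called first, only, known or untested is meant among the compounds shown, and "the series" means these compounds.

Compound 1 `CCc1cc(-c2ccc(F)cc2)c(O)cc1OCCCOc1cccc(CCCCC(=O)N(C)C)c1CCC(=O)O`: 3.1 nM
Compound 2 `CCCc1c(OCCCOc2cc(O)c(-c3ccccc3)cc2CC)ccc2c1OC(C(=O)O)CC2`: 3.3 nM

Of the compounds shown here, two have been tested in an assay on isolated protein for binding affinity to leukotriene B4 receptor (Homo sapiens); on this read-out higher numbers stand for weaker inhibition and lower numbers for stronger inhibition. Compound 1 gives 3.1 nM, and compound 2 gives 3.3 nM. Of these two numbers, that of compound 2 is the higher, but the gap between them lies within the usual scatter of repeated measurements, so the two compounds cannot be told apart on this read-out.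

Compound 3 `CCCc1c(OCCCOc2cc(O)c(-c3ccc(F)cc3)cc2CC)ccc2c1OC(C(=O)O)CC2` has not yet been measured. It differs from compound 2 in one place: fluoro in place of hydrogen on an aromatic carbon. Going by the values given here, no pair of measured compounds differs in this way alone, so no measured step shows what the change does. Compound 1 already carries the fluoro group on a different core and gives 3.1 nM, a number within the scatter of compound 2, which suggests the change matters little here. The step from compound 2 to compound 3 is therefore expected to stay within the scatter, in either direction: a 1.1-fold lower number from compound 2 to compound 3 (0.04 log units; within the scatter). Compound 3 is estimated at 3 nM, with a likely range from 1.3 nM to 7 nM.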

Compound 3, inhibition constant: 3.8 nM
Compound 3: middle estimate off by 1.3-fold (0.10 log units), on the low side; the measured number falls inside the stated range.
By their numbers in this assay, from the lowest: compounds 1, 2 and 3 (each within the scatter of the next).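

On the shared core, the change from phenyl to 4-fluorophenyl gives a 1.2-fold higher number from compound 2 to compound 3 (0.06 log units; within the scatter) in this assay as a direct reading of this one change. Going by these compounds alone, until now the fluoro group had been seen only on the different core of compound 1, where its part could not be separated from the other differences; here, on an aromatic carbon para to a large group, it leaves compound 2 and compound 3 indistinguishable on this read-out. Nothing measured here bears on why the step is this small.

The compounds shown carry only hydrogen or fluoro at this place, so what a chloro group, a methoxy group or an amine would do there stays open. Also open is whether the step reads the same on the core of compound 1, which has no plain phenyl partner among the compounds shown.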